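Phenyl for dichlorophenyl across two related cores

A few compounds are considered here, and "the series" means these few. Any claim that something is new, unique, unknown or untested is made for them only; others in the source may bear on it.

Compound 1 `Cc1nc(Nc2ccc(Cl)c(Cl)c2)sc1C(=O)/C=C/c1ccccc1` carries a 3,4-dichlorophenyl group. In a functional assay on Bel-7402 cells (Homo sapiens) for cytotoxicity, read by MTT assay (a lower number here means a stronger inhibitor, a higher number a weaker inhibitor), compound 1 gives 21500 nM. Compound 2 `Cc1nc(Nc2ccccc2)sc1C(=O)/C=C/c1ccccc1` is the phenyl counterpart of compound 1. In this assay compound 2 gives only a limit, > 25000 nM. The change between the pair is phenyl in place of 3,4-dichlorophenyl on a nitrogen on an aromatic ring, and its step is an at least 1.1-fold higher number from compound 1 to compound 2 (0.06 log units; that floor lies within the scatter). The floor of that step follows from the limit of > 25000 nM in this assay, at which 2 of the 3 values shown sit, the limit at which the value of compound 2 sits.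

Compound 3 `COc1cc(/C=C/C(=O)c2sc(Nc3ccc(Cl)c(Cl)c3)nc2C)cc(OC)c1OC` differs from compound 1 in more than one place; the difference between the two cores is not broken down here. In this assay compound 3 gives only a limit, > 25000 nM.

Compound 4 `COc1cc(/C=C/C(=O)c2sc(Nc3ccccc3)nc2C)cc(OC)c1OC` has not yet been measured in this assay. It relates to compound 3 by phenyl in place of 3,4-dichlorophenyl on a nitrogen on an aromatic ring, the same change, at the same place, that joins compound 1 to compound 2. The step from compound 3 to compound 4 is expected to be a step that the limit leaves unreadable from compound 3 to compound 4, because an at least 1.1-fold higher number from compound 1 to compound 2 (0.06 log units; that floor lies within the scatter) ran toward a weaker number rather than a stronger one. Within the data shown here, compound 3 already stands at a limit in this assay, and nothing among the measured compounds points to a return to a measurable number.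

Compound 4 is therefore expected to give 40000 nM in this assay. The estimated range for compound 4 runs from 25000 nM to 120000 nM, and in most runs only a limit is expected to be reported.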

Compound 4, half-maximal inhibitory concentration: > 25000 nM
Compound 4 ended at the assay's limit; the forecaster's own chance of this, stated with the estimate: 88%; the middle value lies beyond the limit too.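

In this assay compound 4 gives > 25000 nM, a limit of the assay. Compound 3 gives > 25000 nM, also a limit, so no step can be read between compound 3 and compound 4, both resting on the same limit: the limit of > 25000 nM in this assay, at which 3 of the 4 values shown sit.

From the compounds shown here alone, whether phenyl in place of 3,4-dichlorophenyl shifts the number at all on the core of compound 3 stays open.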